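The source may report more compounds than this note shows. Statements on the series, on what has been measured and on what is new or still open speak of the compounds shown alone.

Three compounds share one core and differ in a single group on an aromatic carbon: compound 1 `COc1ccc(NC(=O)C2(C(=O)Nc3ccc(Nc4ncc5cc(C(=O)N(C)C)n(C6CCCC6)c5n4)cc3)CC2)cc1` carries methoxy, compound 2 `Cc1ccc(NC(=O)C2(C(=O)Nc3ccc(Nc4ncc5cc(C(=O)N(C)C)n(C6CCCC6)c5n4)cc3)CC2)cc1` carries methyl and compound 3 `CN(C)C(=O)c1cc2cnc(Nc3ccc(NC(=O)C4(C(=O)Nc5ccc(C(F)(F)F)cc5)CC4)cc3)nc2n1C1CCCC1` carries trifluoromethyl. In a functional assay on T47D cells (Homo sapiens) for inhibition, read by CCK-8 assay, with a stated time of 72 h, tested at 1 uM (on this read-out higher numbers stand for more inhibition of growth at the one concentration tested and lower numbers for less inhibition of growth), compound 1 gives 76.4%, compound 2 gives 47.9% and compound 3 gives 29.6%, so compound 3 stands lowest of the three.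

The next compound is compound 4 `CN(C)C(=O)c1cc2cnc(Nc3ccc(NC(=O)C4(C(=O)Nc5ccc(O)cc5)CC4)cc3)nc2n1C1CCCC1`, which has hydroxy in place of trifluoromethyl on that aromatic carbon, para to a large group (hydroxy in place of trifluoromethyl on an aromatic carbon). Within the data shown here, no hydroxy compound has been measured yet, so no step bears on this change directly. Three measured steps give the scale instead. Methyl in place of methoxy gives a number 28.5 percentage points lower from compound 1 to compound 2 (beyond the scatter), trifluoromethyl in place of methyl gives a number 18.3 percentage points lower from compound 2 to compound 3 (beyond the scatter), and trifluoromethyl in place of methoxy gives a number 46.8 percentage points lower from compound 1 to compound 3 (beyond the scatter).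

Among the measured compounds shown here, the closest guide is compound 1 at 76.4%, the only other compound here with oxygen on that carbon. Hydroxy and methoxy may still differ, and these data cannot show by how much. A rise of modest size is therefore expected, estimated as a number 25.4 percentage points higher from compound 3 to compound 4 (beyond the scatter). For compound 4 the estimated value in this assay is 55%, with an expected range from 30% to 78%.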

Compound 4, percent growth inhibition at one concentration: 91.5%
Beside the measured number, compound 4's estimate is 36.5 percentage points below it, and the stated range ends below it.
By their numbers in this assay, from the lowest: compound 3; then compound 2; then compound 1; then compound 4.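

In this assay the group on this aromatic carbon can shift growth inhibition a long way: hydroxy in place of trifluoromethyl gives a number 61.9 percentage points higher from compound 3 to compound 4 (beyond the scatter) and hydroxy in place of methyl gives a number 43.6 percentage points higher from compound 2 to compound 4 (beyond the scatter) and so places compound 4 highest of the four compounds. The smallest possible edit of the methoxy group, hydrogen in place of methyl on the oxygen, still gives a number 15.1 percentage points higher from compound 1 to compound 4 (beyond the scatter) and shows that having oxygen on this carbon does not settle the number alone, as hydroxy and methoxy are not interchangeable here. Nothing available here explains why these groups differ in this way.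

The compounds shown leave open whether an amine, a carboxylic acid or a longer ether such as ethoxy on this carbon would land nearer to hydroxy or to methoxy, and whether hydroxy would give a similar result on a different aromatic carbon of that ring. From the compounds shown here alone, all four numbers also come from a single concentration in one cell line, so it remains open whether the same order would hold at other concentrations or in other cells.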